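The source may hold more compounds than are shown below. What is called first, only, known or untested is meant among the compounds shown, and "the series" means these compounds.

Measured compounds:
compound 1 `NS(=O)(=O)c1ccc(S(=O)(=O)Nc2cccc(-c3nc(-c4ccc(NC(=O)c5cccnc5)cc4Cl)no3)c2)cc1` — > 10000 nM
compound 2 `CC(=O)Nc1ccc(S(=O)(=O)Nc2cccc(-c3nc(-c4ccc(NC(=O)c5cccnc5)c(C(F)(F)F)c4)no3)c2)cc1` — > 10000 nM
compound 3 `CC(=O)Nc1ccc(S(=O)(=O)Nc2cccc(-c3nc(-c4ccc(NC(=O)c5cccnc5)cc4C(F)(F)F)no3)c2)cc1` — > 10000 nM

In a functional assay on MDA-MB-231 cells (Homo sapiens) for antiproliferative activity, read by MTT assay, with a stated time of 72 h (on this read-out lower numbers stand for stronger inhibition and higher numbers for weaker inhibition), compound 1 gives only a limit, > 10000 nM, and no number. Compound 2 likewise gives a limit in this assay, > 10000 nM. Compound 3 also stands at a limit, > 10000 nM. Compound 1 therefore sits at the edge of what this assay can report, because the limit of > 10000 nM in this assay, at which 3 of the 3 values shown sit, places every value shown there. Compound 4 `O=C(Nc1ccc(-c2noc(-c3cccc(NS(=O)(=O)c4ccc(NC(=O)N5CCCCC5)cc4)c3)n2)c(Cl)c1)c1cccnc1` differs from compound 1 in one place: ((piperidin-1-yl)carbonyl)amino in place of sulfamoyl on an aromatic carbon. Among the compounds with values here, with no measured step between compounds to go by, the step from compound 1 to compound 4 is expected to stay within the scatter, as a step that the limit leaves unreadable from compound 1 to compound 4. Compound 4 is therefore estimated at 12000 nM, between 4000 nM and 40000 nM, most likely again reported only as a limit.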

Compound 4, half-maximal inhibitory concentration: > 10000 nM
Compound 4 ended at the assay's limit; the forecaster's own chance of this, stated with the estimate: 70%; the middle value does not contradict the limit.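

No step can be read between compound 1 and compound 4, because both stand at a limit and neither gives a number: the limit of > 10000 nM in this assay, at which 4 of the 4 values shown sit.

The compounds shown leave open how strongly any of them acts in this assay, and whether ((piperidin-1-yl)carbonyl)amino in place of sulfamoyl changes that.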